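The compounds below may be only part of what the source reports. "The series", "measured", "known", "first", "only" and "open" are said of these compounds alone.

The measured compounds are: compound 1 `N/C(=N\NC(=S)N1CCCC1)c1ccc(F)cn1`, which in a functional assay on MCF7 cells (Homo sapiens) for cytotoxicity, read by MTT assay, with a stated time of 72 h, tested at 3 uM (a lower number here means less inhibition of growth, a higher number more inhibition of growth at the concentration tested), gives 52.6%; compound 2 `Cc1cccc(/C(N)=N/NC(=S)N2CCSCC2)n1`, which gives 20.6%; and compound 3 `N/C(=N\NC(=S)N1CCSCC1)c1ccccn1`, which gives 29%.

Compound 3 stands second highest of the three numbers. Its nearest neighbour is compound 2, whose value lies within the scatter of it, while compound 1 lies beyond the scatter, with the higher number. Among the measured compounds shown here, the only single-point step among the measured compounds, a number 8.4 percentage points higher from compound 2 to compound 3 (within the scatter), concerns a methyl and does not bear on the change to compound 4 `N/C(=N\NC(=S)N1CCSCC1)c1ccc(F)cn1`, which is fluoro in place of hydrogen on an aromatic carbon. For the measured compounds named here, no measured pair isolates this change. Compound 1 carries the same fluoro and gives the highest number, but it also differs in its saturated ring, so its value gives only a hint of direction. A rise within the scatter is therefore expected, a number 9 percentage points higher from compound 3 to compound 4 (within the scatter). Compound 4 is expected to give 38% in this assay, in the range 24% to 52%.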

Compound 4, percent growth inhibition at one concentration: 35.4%
Compound 4: middle estimate off by 2.6 percentage points, on the high side; measured number inside the range.
By their numbers in this assay, from the lowest: compounds 2, 3 and 4 (each within the scatter of the next, the first and the last beyond it); then compound 1.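

In this assay, fluoro in place of hydrogen on the aromatic carbon para to a large group now stands as a single change, and it gives a number 6.4 percentage points higher from compound 3 to compound 4 (within the scatter). With the fluoro held fixed, thiomorpholin-4-yl in place of pyrrolidin-1-yl on the thiocarbonyl carbon gives a number 17.2 percentage points lower from compound 1 to compound 4 (beyond the scatter), so the change in the saturated ring, unlike the fluoro, goes beyond the scatter. No available evidence explains either step.

On these data alone, whether chloro, methoxy or an amine at this position would move the number beyond the scatter remains open. Also open, as far as these compounds go, is whether fluoro counts for more alongside pyrrolidin-1-yl.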